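Extending the amine alkyl group of compound 3

The source may report more compounds than this note shows. Statements on the series, on what has been measured and on what is new or still open speak of the compounds shown alone.

Compound 1 `NCCCOc1cccc2ccccc12`: 290 nM
Compound 2 `CNCCCOc1ccccc1`: 3450 nM
Compound 3 `CNCCOc1cccc2ccccc12`: 26 nM

Of the compounds shown here, three have been measured in a functional assay for agonist activity at 5-hydroxytryptamine receptor 1B (Homo sapiens); a lower number here means a stronger inhibitor, a higher number a weaker inhibitor. Compound 1 `NCCCOc1cccc2ccccc12` gives 290 nM, compound 2 `CNCCCOc1ccccc1` gives 3450 nM, and compound 3 `CNCCOc1cccc2ccccc12` gives 26 nM. Compound 3 stands lowest of the three; its nearest neighbour is compound 1, and compound 2 lies furthest from it. Within the data shown here, the only single-point step among them, an 11-fold lower number from compound 1 to compound 3 (1.05 log units; beyond the scatter), is large and runs in the direction of a lower number.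

Compound 4 `CCCNCCOc1cccc2ccccc12` has not yet been measured. It differs from compound 3 by ethyl in place of hydrogen on a saturated chain carbon bound to an amine nitrogen. Among the measured compounds shown here, no measured step touches this change: the step from compound 1 to compound 3 alters the amine substitution together with the chain length, and compound 2 differs from compound 3 in two places at once, so the two values of compound 2 and compound 3 show only that the pair is far apart. The expectation for compound 4 therefore rests on the strength of compound 3 as the starting point, with some allowance for the longer alkyl group. Compound 4 is expected to give 60 nM, with a range of 15 nM to 300 nM. The step that this estimate for compound 4 would mean is expected to be a 2.3-fold higher number from compound 3 to compound 4 (0.36 log units; beyond the scatter), a modest move towards a higher number.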

Compound 4, inhibition constant: 200 nM
Compound 4: the middle estimate sits 3.3-fold (0.52 log units) below what was measured, and the stated range covers the measured number.
By their numbers in this assay, from the lowest: compound 3; then compounds 4 and 1 (each within the scatter of the next); then compound 2.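

In this assay, among these compounds, the change from methylamino to propylamino gives the first direct reading of the amine alkyl group on the core of compound 3: ethyl in place of hydrogen on a saturated chain carbon bound to an amine nitrogen gives a 7.7-fold higher number from compound 3 to compound 4 (0.89 log units; beyond the scatter), so the low number of compound 3 is not kept when this alkyl group is extended. The comparison with compound 1 adds a second point, a 1.5-fold lower number from compound 1 to compound 4 (0.16 log units; within the scatter), which places compound 4 and compound 1 within the scatter of each other and means that the advantage seen in an 11-fold lower number from compound 1 to compound 3 (1.05 log units; beyond the scatter) is no longer visible once the propylamino group is present. No supporting data bear on why the extension raises the number, and the step itself describes only the size and direction of the change.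

With only methylamino and propylamino compared directly, the compounds shown do not say whether an ethylamino, isopropylamino or dimethylamino group would stay close to compound 3 or fall close to compound 4. They also leave open whether the same methyl to propyl change would produce a step of similar size on the core of compound 2.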